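A Sulfonamide in Place of an Aryl Sulfone

A few compounds are considered here, and "the series" means these few. Any claim that something is new, unique, unknown or untested is made for them only; others in the source may bear on it.

Three ureas have been measured in an assay on isolated protein for activation of Nicotinamide phosphoribosyltransferase (Homo sapiens); on this read-out lower numbers stand for an effect already at smaller amounts and higher numbers for an effect only at larger amounts of compound. Compound 1 `CCOC(=O)c1ccc(NC(=O)NCc2cocn2)cc1` gives 27600 nM. Compound 2 `O=C(NCc1ccncc1)Nc1ccc(S(=O)(=O)c2cccc(Cl)c2)cc1` gives 69 nM, and compound 3 `O=C(NCc1cnco1)Nc1ccc(S(=O)(=O)c2ccccc2)cc1` gives 77 nM. Compound 2 and compound 3 lie within the usual scatter of each other, while both stand far from compound 1. Compound 4 `CCN(CC)S(=O)(=O)c1ccc(NC(=O)NCc2ccncc2)cc1` has not yet been measured in this assay. It differs from compound 2 in one place: diethylamino in place of 3-chlorophenyl on a sulfonyl sulfur. Among the measured compounds shown here, no measured pair shows what this exchange does, so no step can be quoted for it. The aryl part on the sulfonyl tolerates some variation, because compound 3 gives 77 nM close to compound 2. A modest rise is nevertheless the expected outcome, and the expected step is a 3.6-fold higher number from compound 2 to compound 4 (0.56 log units; beyond the scatter). For compound 4 the estimate is 250 nM, between 60 nM and 1500 nM.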

Compound 4, half-maximal effective concentration: 384 nM
For compound 4 the middle estimate is 1.5-fold (0.19 log units) below the measured one; low and high end bracket the measured number.
By their numbers in this assay, from the lowest: compounds 2 and 3 (each within the scatter of the next); then compound 4; then compound 1.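

With diethylamino in place of 3-chlorophenyl on a sulfonyl sulfur, this assay shows a 5.6-fold higher number from compound 2 to compound 4 (0.75 log units; beyond the scatter). Among the compounds shown here, the exchange therefore raises the number, yet a sulfonyl group carrying no ring keeps compound 4 in a measurable range, something the earlier compounds, whose sulfonyl groups all carry an aromatic ring, could not show. No measurement at hand accounts for this step. From the compounds shown here alone, it remains open whether a smaller amine such as dimethylamino, or a cyclic one such as piperidine, would give a number closer to that of compound 2.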